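This account rests on a few compounds, and the source may have more. Where it says the series, first, only, none or still open, it means among the compounds named here.

Measured so far in an assay on isolated protein for inhibition of long-chain fatty acid transport protein 1 (Mus musculus), read by scintillation counting, with a stated time of 20 min; a higher number here means a weaker inhibitor, a lower number a stronger inhibitor:
Compound 1 `O=C(CN1CCN(C2CCCCC2)CC1)Nc1nc2c(s1)CCCC2` gives > 10000 nM, a limit of the assay rather than a number.
Compound 2 `O=C(CN1CCN(c2ccc(F)cc2)CC1)Nc1nc2c(o1)CCCC2` gives 5400 nM.
Compound 3 `O=C(CN1CCN(c2ccc(F)cn2)CC1)Nc1nc2c(o1)CCCC2` gives 1700 nM.

Compound 1 therefore stands only at the limit (the limit of > 10000 nM in this assay, at which 1 of the 3 values shown sits), with no exact number. Compound 4 `O=C(CN1CCN(c2nccs2)CC1)Nc1nc2c(s1)CCCC2` differs from it in one place: 1,3-thiazol-2-yl in place of cyclohexyl on an amine nitrogen in a ring. Among the measured compounds shown here, no measured pair makes exactly this change. The nearest is the step of a 3.2-fold lower number from compound 2 to compound 3 (0.50 log units; beyond the scatter), where one aromatic group replaces another on the same ring nitrogen and the number falls modestly. Here an aromatic group replaces a non-aromatic one, a larger change, so a move toward a lower number is expected, with wide uncertainty. Compound 4 is estimated at 4000 nM, within 1000 nM to 15000 nM, meaning the expected step of an at least 2.5-fold lower number from compound 1 to compound 4 (0.39 log units; beyond the scatter).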

Compound 4, half-maximal inhibitory concentration: 7900 nM
Compound 4: middle estimate off by 2.0-fold (0.30 log units), on the low side; the range from low to high includes it.
By their numbers in this assay, from the lowest: compound 3; then compounds 2 and 4 (each within the scatter of the next). At a limit, above all of these: compound 1.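

Placing 1,3-thiazol-2-yl in place of cyclohexyl on this amine nitrogen in a ring gives a number that can be read in this assay, and the change is an at least 1.2-fold lower number from compound 1 to compound 4 (0.10 log units; that floor lies within the scatter), so even a small gain cannot be ruled out. On these data alone, the full size of this step stays unknown because compound 1 has only a limit: the limit of > 10000 nM in this assay, at which 1 of the 4 values shown sits.

As far as these compounds go, whether a plain phenyl or a pyridin-2-yl at this position would give a lower number remains open. So does whether a carboxylic acid on the thiazole ring would change the number.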